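Shortening the Tail of a Peroxide Ester

The compounds below may be only part of what the source reports. "The series", "measured", "known", "first", "only" and "open" are said of these compounds alone.

Compound 1, `C/C=C/C=C/CCCCCCCCC[C@]1(OC)C=C[C@H](CC(=O)OC)OO1`: 50%
Compound 2, `CCCCCCCCCCCCCCC[C@@]1(OC)C=C[C@H](CC(=O)OC)OO1`: 50%

In a functional assay on P388 cells (Mus musculus) for cytotoxicity, tested at 0.05 ug/mL (a lower number here means less inhibition, a higher number more inhibition at the concentration tested (going by the name of the read-out)), compound 1 gives 50%. Compound 2 gives 50% in this assay, so the two stand level within the scatter, and nothing separates them at the digits shown. Compound 2 differs from compound 1 only in the long chain, and this difference does not show in the numbers.

Compound 3, `C/C=C/CCCCCCCCC[C@]1(OC)C=C[C@H](CC(=O)OC)OO1`, has not yet been measured. It differs from compound 1 by methyl in place of prop-1-en-1-yl on a double-bonded chain carbon bound to a double-bonded chain carbon. Since the shift in the chain between compound 1 and compound 2 left this assay unchanged, no step beyond the scatter is expected here either; the step from compound 1 to compound 3 is estimated at no change at the digits printed from compound 1 to compound 3 (within the scatter). Compound 3 is therefore expected to give about 50% in this assay, in a range from 30% to 70%.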

Compound 3, a percentage reported as inhibition, at one concentration (the size of the read-out at that concentration, not a potency): 50%
For compound 3 middle estimate and measured number coincide at the digits printed, and the stated range covers the measured number.
By their numbers in this assay, from the lowest: compounds 1, 2 and 3 (each within the scatter of the next).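

In this assay, putting methyl in place of prop-1-en-1-yl on a double-bonded chain carbon bound to a double-bonded chain carbon gives no change at the digits printed from compound 1 to compound 3 (within the scatter). The earlier pair showed only that the long chain could differ in its double bonds, whereas this change also removes part of the chain's end, and the read-out still stays level. No separate measurement is available to explain this level result.

Going by these compounds, a reading at a single concentration gives the size of the inhibition rather than a potency, so it remains open whether these compounds would also match across a range of concentrations. Also open, on these data alone, is whether the level would hold with a much shorter chain, an amine at the chain's end, or a carboxylic acid in place of the ester.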